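Changing the sulfonamide aryl group of a chemokine receptor binder

The source may hold more compounds than are shown below. What is called first, only, known or untested is meant among the compounds shown, and "the series" means these compounds.

For the measured compounds named here, compound 1 `O=C(NCc1ccc(CNS(=O)(=O)c2ccc3c(c2)CCO3)cc1)c1ccc(F)cc1` is measured in an assay on MDA-MB-231 cells for binding affinity to C-X-C chemokine receptor type 4 (Homo sapiens), read by fluorescence and microscopy, with stated times of 10 min and 30 min (on this read-out higher numbers stand for an effect only at larger amounts of compound and lower numbers for an effect already at smaller amounts), where compound 1 gives 10 nM, the only numerical value in this set. Compound 2 `Cc1ccc(S(=O)(=O)NCc2ccc(CNC(=O)c3ccc(F)nc3)cc2)cc1` in this assay gives > 1000 nM, which is a limit of the assay and not a number. Going by the values given here, this reflects (the limit of > 1000 nM in this assay, at which 1 of the 2 values shown sits), so compound 1 stands alone as the sole compound with a quantified affinity here. Compound 3 `O=C(NCc1ccc(CNS(=O)(=O)c2ccc(Cl)cc2)cc1)c1ccc(F)cc1` has not yet been measured in this assay. Relative to compound 1, it carries a group of 7 heavy atoms (6 carbon, 1 chlorine; one six-membered aromatic ring of carbon only) in place of a group of 9 heavy atoms (8 carbon, 1 oxygen; one five-membered non-aromatic ring with 1 hetero atom, one six-membered aromatic ring of carbon only), on a sulfonyl sulfur. Among the compounds with values here, with no measured step between a pair of compounds differing in one place, the direction and size of this change cannot be read from the data. The author expects a modest loss, with a step of a 5.0-fold higher number from compound 1 to compound 3 (0.70 log units; beyond the scatter) going beyond the scatter in the direction of weaker binding. Compound 3 is therefore estimated at 50 nM, within a range from 10 nM to 300 nM.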

Compound 3, effective concentration (reported as EC, without a stated level of effect): 100 nM
Compound 3: middle estimate off by 2.0-fold (0.30 log units), on the low side; low and high end bracket the measured number.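

For the compounds shown here, putting 4-chlorophenyl on the sulfonyl sulfur, whose other neighbour is the sulfonamide nitrogen, gives a 10-fold higher number from compound 1 to compound 3 (1.00 log units; beyond the scatter) in this assay, the first measured step at this position. The five-membered non-aromatic ring and the oxygen of the group in compound 1 are therefore not needed for a numerical value, since compound 3 still gives 100 nM on the same core, although the step lies beyond the usual scatter. Nothing shown here accounts for the size or direction of this step.

The step removes that ring and adds chlorine at once, so their separate contributions cannot be read. A plain phenyl group or a methoxyphenyl group at the same place could divide them, while compound 2 differs from compound 1 in more than one place and provides no readable step.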